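A few compounds are considered here, and "the series" means these few. Any claim that something is new, unique, unknown or untested is made for them only; others in the source may bear on it.

Measured so far in a functional assay on HEK293 cells for agonist activity at Free fatty acid receptor 1 (Homo sapiens), read by fluorescence and calcium flux, with a stated time of 10 min; a lower number here means that less compound is needed, a higher number that more compound is needed for the effect:
compound 1 `O=C(O)CC(c1ccc(F)cc1)c1ccc(OCC2COc3ccc(Cl)cc3O2)cc1`, 4310 nM
compound 2 `CC#C[C@H](CC(=O)O)c1ccc(OC[C@H]2COc3ccc(Cl)cc3O2)cc1`, 3400 nM
compound 3 `CC#C[C@@H](CC(=O)O)c1ccc(OC[C@H]2COc3c(Cl)cccc3O2)cc1`, 170 nM

Compound 3 holds the lowest of the three numbers; compound 2 is its nearest and lies beyond the scatter above it, compound 1 further still. Among the compounds with values here, compound 2 and compound 3 differ in more than one place, so their values show only that the pair is far apart. Compound 4 `CC#C[C@@H](CC(=O)O)c1ccc(OC[C@H]2COc3ccccc3O2)cc1` is not yet measured in this assay; it differs from compound 3 in one place: hydrogen in place of chloro on an aromatic carbon. Within the data shown here, no measured pair isolates this change. The step is expected to raise the number moderately, a 2.9-fold higher number from compound 3 to compound 4 (0.47 log units; beyond the scatter), beyond the scatter. Compound 4 is therefore estimated at 500 nM, within 150 nM to 2000 nM.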

Compound 4, half-maximal effective concentration: 90 nM
Compound 4: middle estimate off by 5.6-fold (0.74 log units), on the high side; the measured number lies below the stated range.
By their numbers in this assay, from the lowest: compounds 4 and 3 (each within the scatter of the next); then compounds 2 and 1 (each within the scatter of the next).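

In this assay, within the data shown here, hydrogen in place of chloro on this aromatic carbon gives a 1.9-fold lower number from compound 3 to compound 4 (0.28 log units; within the scatter) and is the first change isolated at a single place. The chloro at this position is therefore not required to keep a number as low as that of compound 3, and the unsubstituted ring serves equally well here. No data on hand account for this result.

Open, from the compounds shown here alone, is whether fluoro, methoxy or a nitrile on this carbon would read the same way. Also open, going by these compounds, is whether the same step holds on the shared core with the opposite configuration at the acid side chain.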